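This account rests on a few compounds, and the source may have more. Where it says the series, first, only, none or still open, it means among the compounds named here.

Values in a functional assay on HCT-116 cells (Homo sapiens) for antiproliferative activity, read by MTT assay, with a stated time of 72 h; on this read-out lower numbers stand for stronger inhibition and higher numbers for weaker inhibition:
- compound 1 `O=S1(=O)C=Cc2cccc(Nc3ccc(Cl)cc3)c21`: 260 nM
- compound 2 `Cc1ccc(Nc2cccc3c2S(=O)(=O)C=C3)cc1`: 4000 nM
- compound 3 `COc1ccc(Nc2cccc3c2S(=O)(=O)C=C3)cc1`: not yet measured

Compound 2 holds the higher of the two numbers. The next change is methoxy in place of methyl on an aromatic carbon, para to a large group. For the measured compounds named here, the only measured step bearing on it is a 15-fold higher number from compound 1 to compound 2 (1.19 log units; beyond the scatter), which is large and involves no methoxy, so it gives only a scale. In this assay a smaller step toward a lower number is expected. The expected step is a 2.7-fold lower number from compound 2 to compound 3 (0.43 log units; beyond the scatter). For compound 3 the estimate is 1500 nM, with an expected range of 350 nM to 6000 nM.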

Compound 3, half-maximal inhibitory concentration: 1990 nM
Compound 3: middle estimate off by 1.3-fold (0.12 log units), on the low side, within the range that was stated.
By their numbers in this assay, from the lowest: compound 1; then compounds 3 and 2 (each within the scatter of the next).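

Methoxy in place of methyl at this carbon, para to a large group, gives a 2.0-fold lower number from compound 2 to compound 3 (0.30 log units; within the scatter) in this assay and so does not separate the two groups. Methoxy in place of chloro gives a 7.7-fold higher number from compound 1 to compound 3 (0.88 log units; beyond the scatter) and shows a second replacement of chloro that leaves a clear gap. Among the three compounds, only compound 1 with chloro stands apart from the others.

As far as these compounds go, whether fluoro, bromo or an amine at this carbon would match chloro remains open. No measurement on hand explains these differences.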